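A few compounds are considered here, and "the series" means these few. Any claim that something is new, unique, unknown or untested is made for them only; others in the source may bear on it.

Measured compounds in the series:
compound 1 `CNC(=O)c1cnc(C(=O)CCc2ccc(COc3ccccc3)cc2)o1` — 3.6 nM
compound 2 `O=C(CCc1ccc(-c2ccccc2)cc1)c1ncc(-c2cccnc2)o1` — 1.1 nM
compound 3 `CNC(=O)c1cnc(C(=O)CCc2ccc(Oc3ccccc3)cc2)o1` — 11 nM

All three numbers come from an assay for inhibition of Fatty-acid amide hydrolase 1 (Rattus norvegicus); a lower number here means a stronger inhibitor, a higher number a weaker inhibitor. Among them compound 1 stands second highest of three: the nearest is compound 3 at 11 nM, the furthest is compound 2 at 1.1 nM.

For the measured compounds named here, the one step between measured compounds that differ in a single place is a 3.1-fold higher number from compound 1 to compound 3 (0.49 log units; beyond the scatter), a modest rise. It concerns the tail of the molecule and not the part changed in compound 4.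

Compound 4 `O=C(O)c1ccc(-c2cnc(C(=O)CCc3ccc(COc4ccccc4)cc3)o2)nc1` is not yet measured. It differs from compound 1 by 5-carboxypyridin-2-yl in place of methylcarbamoyl on an aromatic carbon. Going by the values given here, no measured step covers this exchange. Among the compounds with values here, compound 2 carries a pyridinyl group on the same side of the core and gives 1.1 nM, but its tail also differs from that of compound 1, so no step can be stated; it shows only that an aromatic group there is compatible with a low number.

Given this, no step beyond the scatter is expected in this assay in either direction, with a wide range; the estimated step is a 1.4-fold higher number from compound 1 to compound 4 (0.14 log units; within the scatter). Compound 4 is estimated at 5 nM, between 1 nM and 30 nM.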

Compound 4, inhibition constant: 4.6 nM
Compound 4: middle estimate off by 1.1-fold (0.04 log units), on the high side; low and high end bracket the measured number.
By their numbers in this assay, from the lowest: compound 2; then compounds 1 and 4 (each within the scatter of the next); then compound 3.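

In this assay, placing 5-carboxypyridin-2-yl instead of methylcarbamoyl on the aromatic carbon next to the ring oxygen gives a 1.3-fold higher number from compound 1 to compound 4 (0.11 log units; within the scatter), so this position accepts a group with a six-membered aromatic ring and a carboxylic acid without a step beyond the scatter. For the compounds shown here, the earlier compounds did not give this reading: compound 2 also carries an aromatic group on this side of the core, but its tail differs, and the only earlier step concerns the tail. Going by these compounds alone, with the phenoxymethyl tail held constant, compound 1 and compound 4 give the first direct reading at this position, and it places the two groups within the scatter of each other. No available evidence bears on this result.

Open, on these data alone, is whether the aromatic ring or the carboxylic acid matters more here; a methyl ester or primary amide in place of the acid on the same pyridine would separate the two. Also open, as far as these compounds go, is whether the phenoxy tail of compound 3 combined with 5-carboxypyridin-2-yl would give a number in line with the separate steps.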